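The compounds below may be only part of what the source reports. "The series", "measured", "known", "first", "only" and "open" are said of these compounds alone.

Three compounds measured in an ADME assay on Caco-2 cells (Homo sapiens) for permeability, in the apical to basolateral direction (on this read-out higher numbers stand for higher permeability and lower numbers for lower permeability), set the scene. Compound 1 `Cc1c(NC(=O)c2ccc(C(C)(C)C)cc2)cccc1-c1ccnc2[nH]c(-c3ccc(C(=O)N4CCOCC4)cc3)nc12` gives 0.02 10^-6 cm/s, compound 2 `Cc1cc(-c2ccnc3[nH]c(-c4cnn(C)c4)nc23)ccc1CNC(=O)c1ccc(C(C)(C)C)cc1` gives 0.2 10^-6 cm/s, and compound 3 `Cn1cc(-c2nc3c(-c4ccc(CNC(=O)c5nc(C6(C)CC6)no5)c(F)c4)ccnc3[nH]2)cn1` gives 2.8 10^-6 cm/s. Compound 3 stands highest of the three; its nearest neighbour is compound 2 with a much lower number, and compound 1 lies furthest down, with both gaps beyond the usual scatter of repeated measurements.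

Compound 4 `Cn1cc(-c2nc3c(-c4ccc(CNC(=O)c5ccc(C(C)(C)C)cn5)c(F)c4)ccnc3[nH]2)cn1` has not yet been measured in this assay. It differs from compound 3 in one place: a group of 10 heavy atoms (9 carbon, 1 nitrogen; one six-membered aromatic ring with 1 hetero atom) in place of a group of 9 heavy atoms (6 carbon, 2 nitrogen, 1 oxygen; one three-membered non-aromatic ring of carbon only, one five-membered aromatic ring with 3 hetero atoms), on a carbonyl carbon. For the measured compounds named here, no measured pair in this set shows the same exchange, so the other compounds give no direct guide to the size of this step.

Compound 4 is therefore expected to stay close to compound 3, and the step of a 1.4-fold higher number from compound 3 to compound 4 (0.15 log units; within the scatter) is estimated to be small, likely within the scatter, with a slight lean upward. The estimate for compound 4 in this assay is 4 10^-6 cm/s, with a plausible range from 1.3 10^-6 cm/s to 12 10^-6 cm/s, anchored on compound 3 because it gives 2.8 10^-6 cm/s.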

Compound 4, apparent permeability: 0.3 10^-6 cm/s
For compound 4 the middle estimate is 13-fold (1.12 log units) above the measured one; the whole stated range lies above it.
By their numbers in this assay, from the lowest: compound 1; then compounds 2 and 4 (each within the scatter of the next); then compound 3.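

In this assay, the group on the carbonyl carbon clearly counts: 5-(tert-butyl)pyridin-2-yl in place of the five-membered aromatic ring bearing a methyl-substituted three-membered carbon ring gives a 9.3-fold lower number from compound 3 to compound 4 (0.97 log units; beyond the scatter). This shows that one exchange at this place, with the amide-type nitrogen and the rest of the molecule unchanged, can shift the read-out by more than the usual scatter. Nothing measured here explains the drop. 

The two groups differ in their rings, their atoms and their substituents all at once, so the compounds shown leave open which of these differences matters. A plain pyridin-2-yl group, or the same five-membered ring carrying a tert-butyl group, would help pull those differences apart.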